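A few compounds are considered here, and "the series" means these few. Any claim that something is new, unique, unknown or untested is made for them only; others in the source may bear on it.

Three compounds share one core, a phenyl ketone carrying a hydroxyl and a methyl, tied through a four-carbon chain to a second aromatic ring that bears a carboxylic acid. Compound 1 `COC(=O)c1ccc(OCCCCOc2ccc(C(=O)CC(C)C)c(O)c2C)cc1` has in an assay on HEK293 cells for positive allosteric modulation of metabotropic glutamate receptor 2 (Rattus norvegicus), read by thallium flux, with a stated time of 2.5 min (a higher number here means that more compound is needed for the effect, a lower number that less compound is needed), the result "not determined" (no result reported), so no number exists for it. Compound 2 `Cc1ccc(C(=O)O)cc1OCCCCOc1ccc(C(=O)CC(C)C)c(O)c1C` gives 454 nM. Compound 3 `Cc1cc(OCCCCOc2ccc(C(=O)CC(C)C)c(O)c2C)ccc1C(=O)O` gives 173 nM, the lowest of the two numbers. For the measured compounds named here, the only measured step is a 2.6-fold lower number from compound 2 to compound 3 (0.42 log units; beyond the scatter), a modest move. Between these two compounds the methyl and the acid on the outer ring stand in different places.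

Compound 4 `Cc1c(OCCCCOc2ccccc2C(=O)O)ccc(C(=O)CC(C)C)c1O` differs from compound 3 in one place: 2-carboxyphenyl in place of 4-carboxy-3-methylphenyl on an oxygen on a saturated carbon. Going by the values given here, no measured pair shows exactly this change, so the step from compound 2 to compound 3 is the only guide, and it shows that shifting the acid and the methyl on this ring moves the number by a modest amount. Taking the acid to the position next to the linking oxygen and dropping the methyl is a change of similar scope, so a shift of modest size in either direction, or none beyond the scatter, is expected. The estimate for compound 4 is 350 nM, within 120 nM to 1100 nM, which corresponds to an expected step of a 2.0-fold higher number from compound 3 to compound 4 (0.31 log units; beyond the scatter).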

Compound 4, half-maximal effective concentration: 415 nM
Compound 4: middle estimate off by 1.2-fold (0.07 log units), on the low side; low and high end bracket the measured number.
By their numbers in this assay, from the lowest: compound 3; then compounds 4 and 2 (each within the scatter of the next).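

In this assay, putting 2-carboxyphenyl in place of 4-carboxy-3-methylphenyl on the chain oxygen gives a 2.4-fold higher number from compound 3 to compound 4 (0.38 log units; beyond the scatter) and so gives up the lower number of compound 3, which now stands clear of both other acids by steps beyond the scatter. Putting the same group in place of 5-carboxy-2-methylphenyl gives a 1.1-fold lower number from compound 2 to compound 4 (0.04 log units; within the scatter) and stays within the scatter, so two outer rings that differ in their acid placement and in having a methyl cannot be told apart here, and having a methyl on the ring does not by itself bring the lower number, as compound 2 carries one too. No measurement at hand explains why the three rings rank in this way.

From the compounds shown here alone, the role of the methyl alone remains open, since every step here changes the acid placement along with it or moves both groups together. Also open, going by these compounds, is whether an amide or a tetrazole could stand in for the carboxylic acid on this ring, and whether a longer chain would change the number.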